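Losing the fluoro group from compound 1

The compounds below may be only part of what the source reports. "The series", "measured", "known", "first", "only" and "open" are said of these compounds alone.

Compound 1 `Fc1ccccc1NN=C1C(Cl)=C(Cl)C(Cl)=C1Cl` is the starting point in a functional assay on RPMI-8226 cells (Homo sapiens) for cytotoxicity, read by MTT assay, with a stated time of 48 h; on this read-out higher numbers stand for weaker inhibition and lower numbers for stronger inhibition. Compound 1 gives > 3000 nM, which is a limit and not a number. Compound 2 `CN(C)N=C1C(Cl)=C(Cl)C(Cl)=C1Cl` gives >= 1300 nM, which is also a limit. The standing of compound 1 is therefore known only as a limit, and no measured number exists yet in this small set.

Compound 3 `ClC1=C(Cl)C(Cl)=C(Cl)C1=NNc1ccccc1` carries hydrogen in place of fluoro on an aromatic carbon, ortho to a large group: hydrogen in place of fluoro on an aromatic carbon. Among the compounds with values here, no two measured compounds differ in one place, so the size of such a change has not been measured. In this assay the expected step is none beyond the usual scatter, a step that the limit leaves unreadable from compound 1 to compound 3. This expectation rests on compound 1, whose limit is > 3000 nM. For compound 3 the estimated half-maximal inhibitory concentration is 4000 nM, with an expected range of 1300 nM to 12000 nM.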

Compound 3, half-maximal inhibitory concentration: 600 nM
For compound 3 the middle estimate is 6.7-fold (0.82 log units) above the measured one, outside the stated range (below it).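

In this assay, within the data shown here, hydrogen in place of fluoro on an aromatic carbon, ortho to a large group, gives an at least 5.0-fold lower number from compound 1 to compound 3 (0.69 log units; beyond the scatter), the first step in this set that can be read at all. Fluoro at this place is therefore not needed for a measured cytotoxic effect on this read-out, and the change goes with a lower number, beyond the scatter. The full size of the step stays unknown, since compound 1 is held only by a limit: the limit of > 3000 nM in this assay, at which 1 of the 3 values shown sits.

As far as these compounds go, only fluoro and hydrogen appear at this carbon, so it remains open whether the step is specific to fluoro or would appear with other groups there. How a chloro, a methoxy or an amine at this carbon would read in this assay is not shown by these compounds.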